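The source may report more compounds than this note shows. Statements on the series, on what has been measured and on what is new or still open speak of the compounds shown alone.

For the measured compounds named here, in a functional assay on HCT-8 cells (Homo sapiens) for cytotoxicity (on this read-out higher numbers stand for an effect only at larger amounts of compound and lower numbers for an effect already at smaller amounts), compound 1 `COC1=C(C)C(=O)/C(=C(O)/C=C/c2ccc(Br)cc2)C(=O)C1(C)C` gives 7.4 ug/mL and compound 2 `COC1=C(C)C(=O)/C(=C(O)/C=C/c2ccccc2OC)C(=O)C1(C)C` gives 4.1 ug/mL, so compound 2 stands within the scatter of the only other measured compound. Compound 3 `COC1=C(C)C(=O)/C(=C(O)/C=C/c2ccc(C)cc2)C(=O)C1(C)C` carries 4-methylphenyl in place of 2-methoxyphenyl on a double-bonded chain carbon bound to a double-bonded chain carbon. Going by the values given here, only one measured step bears on this change, a 1.8-fold lower number from compound 1 to compound 2 (0.26 log units; within the scatter), which likewise exchanged one substituted phenyl for another. No shift beyond the scatter is therefore expected in this assay, and the estimated step is a 1.3-fold higher number from compound 2 to compound 3 (0.13 log units; within the scatter). For compound 3 the expected value is 5.5 ug/mL, with an estimated range of 2.5 ug/mL to 12 ug/mL.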

Compound 3, concentration for half-maximal effect: 4.1 ug/mL
Compound 3: middle estimate off by 1.3-fold (0.13 log units), on the high side; measured number inside the range.
By their numbers in this assay, from the lowest: compounds 2, 3 and 1 (each within the scatter of the next).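

In this assay, the exchange of 2-methoxyphenyl for 4-methylphenyl gives no change at the digits printed from compound 2 to compound 3 (within the scatter), and methyl in place of bromo on an aromatic carbon gives a 1.8-fold lower number from compound 1 to compound 3 (0.26 log units; within the scatter). All three substituted phenyl groups at this place therefore lie within the scatter of one another, and the hydrogen-bond acceptor of 2-methoxyphenyl is not required to hold the number at this level. No measurement here accounts for this. Going by these compounds, it remains open whether an amine or a carboxylic acid on the phenyl would move the number beyond the scatter.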